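The source may hold more compounds than are shown below. What is called first, only, known or untested is meant among the compounds shown, and "the series" means these compounds.

Going by the values given here, compound 1 `CC1=CC[C@H](C(C)(C)NC(=S)N/N=C/c2ccccc2O)CC1` is one of two compounds measured in a functional assay on HT-29 cells (Homo sapiens) for inhibition, read by sulforhodamine B assay, with a stated time of 48 h (on this read-out higher numbers stand for weaker inhibition of growth and lower numbers for stronger inhibition of growth), where compound 1 gives 10900 nM, the highest of the two numbers. The other is compound 2 `CC1=CC[C@H](C(C)(C)NC(=S)N/N=C/c2cccc(Cl)c2)CC1`, which in this assay gives 7900 nM; the step of a 1.4-fold lower number from compound 1 to compound 2 (0.14 log units; within the scatter), a 3-chlorophenyl in place of a 2-hydroxyphenyl on the carbon with a double bond to nitrogen, lies within the scatter, so the two values cannot be ordered. Compound 3 `CC1=CC[C@H](C(C)(C)NC(=S)N/N=C/c2ccccc2[N+](=O)[O-])CC1` has not yet been measured in this assay. It differs from compound 1 by nitro in place of hydroxy on an aromatic carbon, the place being an aromatic carbon of a six-membered aromatic ring of carbon only, ortho to a large group. Among the compounds with values here, the only measured step that bears on this change is the one from compound 1 to compound 2, which also alters the substituent on that same aromatic ring and stayed within the scatter. On that basis no step beyond the scatter is expected in this assay, in either direction. The expected size of the step is a 1.1-fold lower number from compound 1 to compound 3 (0.06 log units; within the scatter). Compound 3 is therefore estimated at 9500 nM, with a range from 3000 nM to 30000 nM.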

Compound 3, concentration for 50% growth inhibition: 7900 nM
Compound 3: the middle estimate sits 1.2-fold (0.08 log units) above what was measured; low and high end bracket the measured number.
By their numbers in this assay, from the lowest: compounds 2, 3 and 1 (each within the scatter of the next).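

In this assay, nitro in place of hydroxy on an aromatic carbon gives a 1.4-fold lower number from compound 1 to compound 3 (0.14 log units; within the scatter), so this exchange does not separate compound 3 from compound 1. The earlier step altered the substituent and where it stood on the ring, whereas this one keeps the place, ortho to a large group, and shows that this place tolerates a substantial change in the group: the hydroxy, with 1 heavy atom and 1 hydrogen-bond donor, gives way to a nitro, with 3 heavy atoms and 0 hydrogen-bond donors, without a step beyond the scatter. Nothing available explains why the number stays within the scatter across this exchange.

The compounds shown leave open whether an amine, a carboxylic acid or a longer chain such as butoxy on the same aromatic carbon would also stay within the scatter of compound 1. They also leave open whether any change to this ring can move the number beyond the scatter, or whether such a step would have to come from another part of the shared core.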